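A few compounds are considered here, and "the series" means these few. Any claim that something is new, unique, unknown or untested is made for them only; others in the source may bear on it.

Compound 1 `Cc1cccc(-n2cc(-c3ccc(NS(=O)(=O)c4c[nH]c(=O)[nH]c4=O)cc3)nn2)c1`: 17500 nM
Compound 2 `Cc1ccc(-n2cc(-c3ccc(NS(=O)(=O)c4c[nH]c(=O)[nH]c4=O)cc3)nn2)cc1`: 8350 nM

In a functional assay on SGC-7901 cells (Homo sapiens) for antiproliferative activity, read by MTT assay, with a stated time of 24 h (a lower number here means a stronger inhibitor, a higher number a weaker inhibitor), compound 2 stands at the lowest of the two numbers; its nearest neighbour is compound 1, and the two are separated by a 2.1-fold lower number from compound 1 to compound 2 (0.32 log units; beyond the scatter). Compound 3 `O=c1[nH]cc(S(=O)(=O)Nc2ccc(-c3cn(-c4ccc(F)cc4)nn3)cc2)c(=O)[nH]1` differs from compound 2 by fluoro in place of methyl on an aromatic carbon. Among the compounds with values here, no measured step exchanges methyl for fluoro; the single measured step, a 2.1-fold lower number from compound 1 to compound 2 (0.32 log units; beyond the scatter), only moves the methyl and bears on this change indirectly. Compound 3 is therefore expected to remain near compound 2, with a 1.1-fold higher number from compound 2 to compound 3 (0.03 log units; within the scatter) not beyond the scatter. Compound 3 is estimated at 9000 nM, within 3000 nM to 27000 nM.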

Compound 3, half-maximal inhibitory concentration: > 20000 nM
Compound 3 gave a limit, no number; the forecaster's own chance of this, stated with the estimate: 5%; middle value at least 2.2-fold (0.34 log units) from the limit.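

In this assay compound 3 gives a limit and not a number: the limit of > 20000 nM in this assay, at which 1 of the 3 values shown sits.

At this place, para to a large group, fluoro does not stand in for methyl: an at least 2.3-fold higher number from compound 2 to compound 3 (0.37 log units; beyond the scatter). The other step, an at least 1.1-fold higher number from compound 1 to compound 3 (0.05 log units; that floor lies within the scatter), has a floor within the scatter, so it sets no order between those two.

Going by these compounds, how far compound 3 lies past its limit stays open. So does whether chloro, methoxy or an amine at this place would read like methyl or like fluoro.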